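Second chloro on the purine core: effect on cytotoxicity

The compounds below may be only part of what the source reports. "The series", "measured", "known", "first", "only" and "open" are said of these compounds alone.

Measured compounds:
- compound 1, `ClCc1ccc(Cn2cnc3c(Cl)ncnc32)cc1`: 2300 nM
- compound 2, `ClCc1ccccc1Cn1cnc2c(Cl)ncnc21`: 440 nM

Both compounds were tested in a functional assay on RXF 393 cells (Homo sapiens) for cytotoxicity, read by sulforhodamine B assay, with a stated time of 48 h; a higher number here means a weaker inhibitor of growth, a lower number a stronger inhibitor of growth. Compound 1 gives 2300 nM, the highest of the two numbers; the nearest is compound 2 with 440 nM, a lower number by a gap beyond the usual scatter, so on these numbers compound 1 is the weaker growth inhibitor of the pair.

Compound 3, `ClCc1ccc(Cn2cnc3c(Cl)nc(Cl)nc32)cc1`, has not yet been measured. It is compound 1 with one change: chloro in place of hydrogen on an aromatic carbon of the shared core. Within the data shown here, no pair of measured compounds differs in only this way, so the size of this step is not known from the data. A change of this kind would be expected to shift the number only a little, if at all, perhaps toward a lower value, but likely within the scatter. The step from compound 1 to compound 3 is therefore estimated as a 1.5-fold lower number from compound 1 to compound 3 (0.19 log units; within the scatter). Compound 3 is expected to give about 1500 nM, in a range from 500 nM to 5000 nM.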

Compound 3, concentration for 50% growth inhibition: 20900 nM
Beside the measured number, compound 3's estimate is 14-fold (1.14 log units) below it, and the stated range ends below it.
By their numbers in this assay, from the lowest: compound 2; then compound 1; then compound 3.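

Chloro in place of hydrogen on an aromatic carbon of the shared core, between two ring nitrogen atoms, is far from a silent change in this assay: it gives a 9.1-fold higher number from compound 1 to compound 3 (0.96 log units; beyond the scatter), which makes compound 3 the weaker growth inhibitor of this pair. Compound 1 and compound 2 both carry hydrogen on this carbon, so they could say nothing about it; this pair now shows that a single added atom here can matter a great deal for growth inhibition. Nothing available explains why the number rises at this position.

A single replacement cannot show whether other groups on this carbon, such as an amine, a methoxy group or fluoro, would also weaken growth inhibition. As far as these compounds go, it also remains open whether the same chloro change would have a similar effect on compound 2.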